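The compounds below may be only part of what the source reports. "The series", "measured", "known", "first", "only" and "open" are said of these compounds alone.

Measured compounds in a functional assay on HepG2 cells (Homo sapiens) for inhibition, read by MTT assay, with a stated time of 48 h (on this read-out lower numbers stand for stronger inhibition and higher numbers for weaker inhibition), are these
- compound 1 `C[Se]c1ccc(N(C)c2nc(C3CC3)nc3ccccc23)cc1` with 32 nM
- compound 2 `COc1ccc(N(C)c2nc(C)nc3ccccc23)cc1OCCCCCC[Se]C#N` with 4890 nM
- compound 3 `Cc1nc(N(C)c2ccc([Se]C#N)c(C)c2)c2ccccc2n1` with 9 nM

Of these three, compound 2 has the highest number, and so the weakest inhibition, at 4890 nM on this read-out. Its distance from the other two lies well beyond the scatter. Compound 1 is the nearer of them and compound 3 the further, both with far lower numbers.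

The next compound to be tested is compound 4 `COc1ccc(N(C)c2nc(C)nc3ccccc23)cc1C(=O)OCCCC[Se]C#N` and it departs from compound 2 in one place. The change is a group of 10 heavy atoms (6 carbon, 1 nitrogen, 2 oxygen, 1 selenium; no ring) in place of a group of 10 heavy atoms (7 carbon, 1 nitrogen, 1 oxygen, 1 selenium; no ring), on an aromatic carbon and it lies on an aromatic carbon of a six-membered aromatic ring of carbon only, ortho to a methoxy group and meta to a large group. The rest of the structure is the same, and the two groups match in heavy-atom count.

Within the data shown here, no measured pair of compounds differs in one place, so the data offer no direct guide to this change. The main anchor is compound 2 at 4890 nM and only a small shift from it in this assay is expected, towards a lower number and not clearly beyond the scatter. The expected size of the change is a 2.0-fold lower number from compound 2 to compound 4 (0.29 log units; within the scatter) on this estimate. For compound 4 the estimated value is 2500 nM with an expected range from 500 nM to 10000 nM in this read-out.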

Compound 4, half-maximal inhibitory concentration: 975 nM
Compound 4: middle estimate off by 2.6-fold (0.41 log units), on the high side; the measured number falls inside the stated range.
By their numbers in this assay, from the lowest: compound 3; then compound 1; then compound 4; then compound 2.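

Among these compounds, until now, no two measured compounds could be compared directly, so nothing showed whether this position responds to a change in its group. In this assay, the step of a 5.0-fold lower number from compound 2 to compound 4 (0.70 log units; beyond the scatter) shows that it does: exchanging one open-chain group for another on this aromatic carbon, ortho to a methoxy group, moves the number beyond the scatter, although the two groups match in heavy-atom count and neither holds a ring. The entering group has 6 carbon and 2 oxygen atoms where the leaving group has 7 carbon and 1 oxygen, and it adds a double bond, but no measured property of these compounds accounts for the shift.

The step changes the link to the ring and the chain together, so the compounds shown cannot separate the contribution of the carbonyl-containing link from that of the chain. Among the compounds shown here, an amide link carrying the same chain, or the same ester link with a longer chain, would tell these two contributions apart, and only one such step at this position is available so far.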